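Same Ring Swap, Seen Once, Expected Again

This account rests on a few compounds, and the source may have more. Where it says the series, first, only, none or still open, it means among the compounds named here.

Measured so far in a functional assay on A-431 cells (Homo sapiens) for cytotoxicity, read by MTT assay, with a stated time of 72 h, tested at 1 uM; a lower number here means less inhibition of growth, a higher number more inhibition of growth at the concentration tested:
compound 1, `Cc1ccnc(/C(N)=N/NC(=S)N2CCOCC2)c1`, gives 33.6%
compound 2, `Cc1cccc(/C(N)=N/NC(=S)N2CCSCC2)n1`, gives 42.8%
compound 3, `Cc1ccnc(/C(N)=N/NC(=S)N2CCSCC2)c1`, gives 34.6%

Compound 2 and compound 3 are built from the same atoms joined differently; the difference between the two cores is not broken down here. Their values in this assay lie within the usual scatter of each other, so nothing can be said about an order between them.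

One change has been measured directly. From compound 3 to compound 1 the step is a number 1 percentage points lower from compound 3 to compound 1 (within the scatter), the change being (morpholin-4-yl in place of thiomorpholin-4-yl on a thiocarbonyl carbon).

Compound 4, `Cc1cccc(/C(N)=N/NC(=S)N2CCOCC2)n1`, has not yet been tested in this assay. It relates to compound 2 as compound 1 relates to compound 3: morpholin-4-yl in place of thiomorpholin-4-yl on a thiocarbonyl carbon. The place of the change is the same in both pairs, so this is the same change. Since that change left the value of compound 3 essentially unmoved, a number 1 percentage points lower from compound 3 to compound 1 (within the scatter), the step from compound 2 to compound 4 is expected to be of the same small size, a number 1 percentage points lower from compound 2 to compound 4 (within the scatter). Compound 4 is therefore estimated at 41.8%, most likely between 31% and 52%.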

Compound 4, percent growth inhibition at one concentration: 47.2%
Compound 4: middle estimate off by 5.4 percentage points, on the low side, and the stated range covers the measured number.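

In this assay the change from thiomorpholin-4-yl to morpholin-4-yl has now been read on a second core, where the step is a number 4.4 percentage points higher from compound 2 to compound 4 (within the scatter). Set beside the earlier step, the two do not differ: the same change on two cores in this assay, a number 1 percentage points lower (within the scatter) from compound 3 to compound 1 and a number 4.4 percentage points higher (within the scatter) from compound 2 to compound 4, 5.4 percentage points apart, within the scatter of two such steps. On these two cores, then, the change can be carried from one to the other without a step that stands out from the scatter, but two pairs tested at one concentration do not show that this holds on any further core, or that the two rings would match in any other measurement.

The compounds shown leave open what a different group on the thiocarbonyl carbon would give, such as a piperazin-1-yl ring or an open-chain dimethylamine. As far as these compounds go, it also remains open whether the picture would stay the same with an ethyl chain in place of the methyl group on the shared core.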